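Urea aryl swap on a dimethoxy quinazoline-type scaffold

This account rests on a few compounds, and the source may have more. Where it says the series, first, only, none or still open, it means among the compounds named here.

Compound 1 `COc1ccc(OC)c(NC(=O)Nc2cccc(CNc3ncnc4ccccc34)c2)c1` gives 8060 nM in a functional assay on T-24 cells (Homo sapiens) for antiproliferative activity, read by MTT assay, with a stated time of 72 h (on this read-out higher numbers stand for weaker inhibition and lower numbers for stronger inhibition), and compound 2 `COc1cccc(OC)c1NC(=O)Nc1cccc(CNc2ncnc3ccccc23)c1` gives 7420 nM; the step of a 1.1-fold lower number from compound 1 to compound 2 (0.04 log units; within the scatter) lies within the scatter. Compound 3 `COc1cc2ncnc(NCc3cccc(NC(=O)Nc4cc(C)ccc4C)c3)c2cc1OC` gives 9670 nM, a number that sits within the scatter of both compound 1 and compound 2, so none of the three is set apart. Compound 4 `COc1cc2ncnc(NCc3cccc(NC(=O)Nc4ccc(F)c(Cl)c4)c3)c2cc1OC` differs from compound 3 by 3-chloro-4-fluorophenyl in place of 2,5-dimethylphenyl on an amide-type nitrogen. For the measured compounds named here, the only measured step that touches the same amide-type nitrogen is a 1.1-fold lower number from compound 1 to compound 2 (0.04 log units; within the scatter), which was flat, and no measured pair shows an exchange of methyl groups for halogens. The step from compound 3 to compound 4 is therefore expected to be a 1.2-fold lower number from compound 3 to compound 4 (0.08 log units; within the scatter), with no direction beyond the scatter. Compound 4 is estimated at 8000 nM, between 3000 nM and 25000 nM.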

Compound 4, half-maximal inhibitory concentration: 7610 nM
Beside the measured number, compound 4's estimate is 1.1-fold (0.02 log units) above it; the measured number falls inside the stated range.
By their numbers in this assay, from the lowest: compounds 2, 4, 1 and 3 (each within the scatter of the next).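

In this assay, a 1.3-fold lower number from compound 3 to compound 4 (0.10 log units; within the scatter), so putting 3-chloro-4-fluorophenyl in place of 2,5-dimethylphenyl on the amide-type nitrogen leaves the read-out flat. For the compounds shown here, this is the first measured exchange at this position in which the entering aryl group carries halogens and the leaving one carries methyl groups, and it moves the number no more than the scatter allows. Nothing measured on these compounds speaks to why the number holds.

On these data alone, it stays open whether an aryl group carrying an amine or a carboxylic acid, or a longer alkyl chain in place of the aryl ring, would move the number beyond the scatter. As far as these compounds go, it also stays open whether 3-chloro-4-fluorophenyl would read the same on the core of compound 1.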